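Chloro for tert-butyl on the aryl sulfide of a benzamide

The compounds below may be only part of what the source reports. "The series", "measured", "known", "first", "only" and "open" are said of these compounds alone.

Measured compounds:
compound 1 `COc1ccc(SCc2ccc(/C=C/C(=O)Nc3ccccc3N)cc2)cc1OC` with 14.3%
compound 2 `Nc1ccccc1NC(=O)/C=C/c1ccc(CSc2cccc3ccccc23)cc1` with 3.7%
compound 3 `CC(C)(C)c1ccc(SCc2ccc(C(=O)Nc3ccccc3N)cc2)cc1` with 23.6%

The three compounds were tested in a functional assay on SMMC-7721 cells (Homo sapiens) for inhibition, read by CCK-8 assay, with a stated time of 72 h, tested at 2 uM; on this read-out lower numbers stand for less inhibition of growth and higher numbers for more inhibition of growth at the one concentration tested. Compound 3 gives the highest number of the three; compound 1 lies within the scatter of it, while compound 2 lies beyond the scatter below it. Among the measured compounds shown here, the one step between compounds that differ in a single place is a number 10.6 percentage points lower from compound 1 to compound 2 (beyond the scatter); it concerns the aryl group on the sulfur, not the substituent examined here.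

Compound 4 `Nc1ccccc1NC(=O)c1ccc(CSc2ccc(Cl)cc2)cc1` is not yet measured. Against compound 3 the change is chloro in place of tert-butyl on an aromatic carbon. For the measured compounds named here, no measured step bears directly on a chloro in place of tert-butyl; the step from compound 1 to compound 2 shows only that exchanging the group on the sulfur can move the number in this range. With nothing more to go on, the expectation for compound 4 is a number near that of compound 3, with a step of a number 5.6 percentage points lower from compound 3 to compound 4 (within the scatter) that may stay within the scatter. The estimate for compound 4 in this assay is therefore 18%, expected between 5% and 32%.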

Compound 4, percent growth inhibition at one concentration: 2.93%
The estimate for compound 4 lay 15.1 percentage points above the measured number; the measured number lies below the stated range.
By their numbers in this assay, from the lowest: compounds 4 and 2 (each within the scatter of the next); then compounds 1 and 3 (each within the scatter of the next).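

In this assay the exchange of tert-butyl for chloro on the aromatic carbon gives a number 20.7 percentage points lower from compound 3 to compound 4 (beyond the scatter), so the group at this one place on the aryl sulfide can move the number on its own. The earlier step, a number 10.6 percentage points lower from compound 1 to compound 2 (beyond the scatter), had exchanged the entire aryl group on the sulfur; this pair shows that a single substituent on that ring, with the rest of the molecule unchanged, can also produce a step beyond the scatter. Nothing measured here accounts for the step.

This single pair leaves open whether the number follows the count of heavy atoms at this place or the identity of the group, which a methyl, an isopropyl or a fluoro there would help to separate. Also open, from the compounds shown here alone, is whether the same exchange would have a similar effect on the core of compound 1.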